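The compounds below may be only part of what the source reports. "The series", "measured", "known", "first", "only" and "open" are said of these compounds alone.

Compound 1 `Nc1ncnc2c1ncn2[C@@H]1O[C@@H]2CO[P@@](=O)(OCc3ccccc3)O[C@H]2[C@H]1O`: 3 h
Compound 2 `Nc1ncnc2c1ncn2[C@@H]1O[C@@H]2CO[P@](=O)(OCc3ccc([N+](=O)[O-])cc3)O[C@H]2[C@H]1O`: 9.5 h

In a physicochemical assay for metabolic stability, at 30 degrees C, at pH 6.5 (on this read-out lower numbers stand for a shorter-lived compound and higher numbers for a longer-lived compound), compound 2 holds the higher of the two numbers at 9.5 h, and compound 1 gives 3 h. The gap between the two lies beyond the scatter. Compound 3 `Nc1ncnc2c1ncn2[C@@H]1O[C@@H]2CO[P@@](=O)(OCc3ccc([N+](=O)[O-])cc3)O[C@H]2[C@H]1O` has not yet been measured. The change from compound 2 is the two compounds have the same atoms and bonds and differ only in configuration as drawn: 1 of 5 stereo elements differ; a stereocentre at a phosphorus is drawn S in compound 2 and R in compound 3. The two compounds have the same atoms and bonds, and a stereocentre at a phosphorus is drawn S in compound 2 and R in compound 3. Going by the values given here, no measured step shows what such a change does on this read-out, so the expectation remains loose. Among the compounds with values here, it leans slightly downward, since the only other number is that of compound 1 at 3 h. The estimated change is a 1.6-fold lower number from compound 2 to compound 3 (0.20 log units; within the scatter), a small fall expected to stay within the scatter. Compound 3 is expected at 6 h, with an estimated range of 2.5 h to 14 h.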

Compound 3, half-life: 3 h
For compound 3 the middle estimate is 2.0-fold (0.30 log units) above the measured one; measured number inside the range.
By their numbers in this assay, from the lowest: compounds 1 and 3 (each within the scatter of the next); then compound 2.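

In this assay, the stereocentre at phosphorus proves able to shift the read-out on its own, with a 3.2-fold lower number from compound 2 to compound 3 (0.50 log units; beyond the scatter). This step can be set on that stereocentre alone because of one thing: the fact that compounds 2 and 3 differ only in the configuration as drawn With the phosphorus drawn as in compound 3, nitro in place of hydrogen on an aromatic carbon gives no change at the digits printed from compound 1 to compound 3 (within the scatter), so the nitro group makes no visible difference in this configuration.

The compounds shown leave open whether the phosphorus configuration matters to the same degree on the plain benzyl group, which appears only in compound 1, drawn as in compound 3. They also leave open whether a methoxy group or a chlorine in place of the nitro would behave as the nitro does in either configuration.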